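Halogen swap on the aryl ketone of compound 1

The source may report more compounds than this note shows. Statements on the series, on what has been measured and on what is new or still open speak of the compounds shown alone.

Of the compounds shown here, three have been read in a functional assay on OVCAR-3 cells (Homo sapiens) for cytotoxicity, read by sulforhodamine B assay, with a stated time of 48 h, tested at 100 uM; on this read-out lower numbers stand for a stronger effect and higher numbers for a weaker effect at the one concentration tested. Compound 1 `COc1cc(-c2cc(/C=C/C(=O)c3ccc(Cl)c(Cl)c3)[nH]n2)cc(OC)c1OC` stands highest of the three: in this assay compound 1 gives -30%, whereas compound 2 `COc1ccc(-c2cc(/C=C/C(=O)c3cc(OC)c(OC)c(OC)c3)[nH]n2)cc1OC` gives -83% and compound 3 `COc1cc(C(=O)/C=C/c2cc(-c3cc(OC)c(OC)c(OC)c3)n[nH]2)cc(OC)c1OC` gives -98%, both beyond the scatter from compound 1. Within the data shown here, the only single-point step measured, a number 15 percentage points lower from compound 2 to compound 3 (beyond the scatter), concerns a methoxy in place of hydrogen on an aromatic carbon and does not touch a halogen.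

Compound 4 `COc1cc(-c2cc(/C=C/C(=O)c3ccc(F)c(F)c3)[nH]n2)cc(OC)c1OC` differs from compound 1 in one place: 3,4-difluorophenyl in place of 3,4-dichlorophenyl on a carbonyl carbon. Among the measured compounds shown here, no measured step bears on this exchange, so no step beyond the scatter is expected in this assay. The estimate for compound 4 is -30%, within -70% to 5%. This expected estimate means no change at the digits printed from compound 1 to compound 4 (within the scatter).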

Compound 4, a percentage reported as activity, at one concentration (the size of the read-out at that concentration, not a potency): -64%
Compound 4: the middle estimate sits 34 percentage points above what was measured; the range from low to high includes it.
By their numbers in this assay, from the lowest: compound 3; then compound 2; then compound 4; then compound 1.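

On the carbonyl carbon, the read-out in this assay depends on which halogens the aryl ring carries: 3,4-difluorophenyl in place of 3,4-dichlorophenyl gives a number 34 percentage points lower from compound 1 to compound 4 (beyond the scatter). The two groups match in heavy atom count, ring, and hydrogen-bond donor and acceptor counts, so a change limited to the halogen atoms is enough to shift the read-out at this position. Among these compounds, this is the first measured step at this position.

Going by these compounds, how 3,4-dibromophenyl or unsubstituted phenyl would read here remains open. No measurement shown bears on the reason for this step.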